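The source may report more compounds than this note shows. Statements on the series, on what has been measured and on what is new or still open speak of the compounds shown alone.

Compounds measured so far:
compound 1, `COc1ccc(/C=C/C[C@H]2C[C@H]([C@H](O)c3ccc(OC)c(OC)c3)CO[C@@H]2c2ccc(OC)c(OC)c2)cc1OC`, 34600 nM;
compound 2, `COc1cccc(/C=C/C[C@H]2C[C@@H]([C@@H](O)c3ccccc3)CO[C@@H]2c2ccccc2)c1`, 10900 nM;
compound 3, `COc1ccc(/C=C/C[C@H]2C[C@@H]([C@@H](O)c3ccc(OC)c(OC)c3)CO[C@@H]2c2ccc(OC)c(OC)c2)cc1OC`, 23800 nM.

All three were tested in a functional assay on HeLa cells (Homo sapiens) for cytotoxicity, read by WST assay, with a stated time of 48 h; a higher number here means a weaker inhibitor, a lower number a stronger inhibitor. Compound 2 gives the lowest number of the three, and the gaps to compound 3 and to compound 1 both lie beyond the scatter. Compounds 1 and 3 share the same atoms and bonds, and the step of a 1.5-fold lower number from compound 1 to compound 3 (0.16 log units; within the scatter) stays within the scatter; this is consistent with the fact that compounds 1 and 3 differ only in the configuration as drawn, since only the drawn configuration separates them.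

Compound 4, `O[C@@H](c1ccccc1)[C@H]1CO[C@H](c2ccccc2)[C@@H](C/C=C/c2ccncc2)C1`, has not yet been measured in this assay. It differs from compound 2 in one place: pyridin-4-yl in place of 3-methoxyphenyl on a double-bonded chain carbon bound to a double-bonded chain carbon. Within the data shown here, no measured step among compounds 1, 2 and 3 touches the group on the double-bonded chain carbon; the only step recorded, between compounds 1 and 3, concerns configuration alone and was within the scatter. Among the measured compounds shown here, there is therefore no direct precedent for the size or direction of this change, and the expectation rests on compound 2 itself.

For compound 4 the estimate is 12000 nM, with a range from 4000 nM to 40000 nM, which is expected to mean a step of a 1.1-fold higher number from compound 2 to compound 4 (0.04 log units; within the scatter).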

Compound 4, half-maximal inhibitory concentration: > 100000 nM
Compound 4: only a limit was reported; the forecaster's own chance of this, stated with the estimate: 10%; at least 8.3-fold (0.92 log units) between middle value and limit.
By their numbers in this assay, from the lowest: compound 2; then compounds 3 and 1 (each within the scatter of the next). At a limit, above all of these: compound 4.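

Putting pyridin-4-yl in place of 3-methoxyphenyl on a double-bonded chain carbon bound to a double-bonded chain carbon gives, in this assay, an at least 9.1-fold higher number from compound 2 to compound 4 (0.96 log units; beyond the scatter), and this is the only step shown that touches this position. The value of compound 4 is a limit of the assay, not a number, so the step gives only a lower bound on the size of the change: the limit of > 100000 nM in this assay, at which 1 of the 4 values shown sits. Among these compounds, the one earlier step, a 1.5-fold lower number from compound 1 to compound 3 (0.16 log units; within the scatter), concerned drawn configuration alone and stayed within the scatter, whereas this change of the aryl group on the chain shows that the number is sensitive to what sits at this place.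

The change removes the methoxy group and brings in a ring nitrogen in a single step, and the compounds shown cannot tell which of the two accounts for the rise. From the compounds shown here alone, how a plain phenyl group would stand at this place, and whether pyridin-4-yl would have the same outcome on the core of compound 3, stays open.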